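Swapping an Aryl Ether for a Benzyl Group

The source may report more compounds than this note shows. Statements on the series, on what has been measured and on what is new or still open speak of the compounds shown alone.

Compound 3 `CC(C)(Oc1ccccc1O)C1OCC(C/C=C\CCC(=O)O)C(c2cccnc2)O1` carries a 2-hydroxyphenoxy group on the shared core. In an assay for inhibition of Thromboxane-A synthase (Homo sapiens), using microsomes (on this read-out higher numbers stand for weaker inhibition and lower numbers for stronger inhibition), compound 3 gives 32 nM, the second highest of the three numbers: compound 1 `N#Cc1ccc(C2OCC(C/C=C\CCC(=O)O)C(c3cccnc3)O2)cc1` gives 24 nM, within the scatter of compound 3, while compound 2 `Cc1ccc(OC(C)(C)C2OCC(C/C=C\CCC(=O)O)C(c3cccnc3)O2)cc1` gives 360 nM. Among the measured compounds shown here, the only measured step, an 11-fold lower number from compound 2 to compound 3 (1.05 log units; beyond the scatter), shows that changing the aryl ring on that oxygen can shift the number a great deal. Compound 4 `CC(C)(Cc1ccccc1)C1OCC(C/C=C\CCC(=O)O)C(c2cccnc2)O1` differs from compound 3 by benzyl in place of 2-hydroxyphenoxy on a saturated chain carbon bound to two saturated chain carbons and a saturated ring carbon. For the measured compounds named here, no measured step removes the oxygen itself, so the large step of an 11-fold lower number from compound 2 to compound 3 (1.05 log units; beyond the scatter) is the sole guide, and it points to a real but uncertain shift. Compound 4 is therefore expected to give 90 nM, plausibly between 25 nM and 350 nM, an expected step of a 2.8-fold higher number from compound 3 to compound 4 (0.45 log units; beyond the scatter).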

Compound 4, half-maximal inhibitory concentration: 12 nM
The estimate for compound 4 lay 7.5-fold (0.88 log units) above the measured number, and the stated range ends above it.
By their numbers in this assay, from the lowest: compounds 4, 1 and 3 (each within the scatter of the next, the first and the last beyond it); then compound 2.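

Benzyl, which has 0 hydrogen-bond donors and 0 hydrogen-bond acceptors, gives a 2.7-fold lower number from compound 3 to compound 4 (0.43 log units; beyond the scatter) and a 30-fold lower number from compound 2 to compound 4 (1.48 log units; beyond the scatter), so a low number at this position needs neither an oxygen on that chain carbon nor a hydrogen-bond donor in the group. With 1-benzyl-1-methylethyl in place of 4-cyanophenyl on a saturated ring carbon, a 2.0-fold lower number from compound 1 to compound 4 (0.30 log units; within the scatter) leaves the two compounds indistinguishable. No available evidence explains these shifts. Still open, from the compounds shown here alone, is how an amine or a carboxylic acid on the benzyl ring would affect the number, and whether a longer chain in place of benzyl would keep it low.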